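Solubility of a dimethylamino azetidine quinolone analogue

The source may report more compounds than this note shows. Statements on the series, on what has been measured and on what is new or still open speak of the compounds shown alone.

Of the compounds shown here, three sharing one fused core have been measured in a physicochemical assay for solubility, at pH 7.4; on this read-out lower numbers stand for lower solubility and higher numbers for higher solubility. Compound 1 `CC[C@H]1[C@@H](N)CN1c1cc2c(cc1F)c(=O)c(C(=O)O)cn2C1CC1` gives 42.2 ug/mL, compound 3 `C[C@H]1[C@H](N)CN1c1c(F)c(N)c2c(=O)c(C(=O)O)cn(C3CC3)c2c1F` gives 37.7 ug/mL, and compound 2 `CNC1CN(c2c(F)cc3c(=O)c(C(=O)O)cn(C4CC4)c3c2F)C1` gives 1.7 ug/mL. Compound 2 stands lowest of the three: both compound 3 and compound 1 give higher numbers, and both gaps lie beyond the scatter of repeated measurements.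

The unmeasured compound 4 `C[C@@H]1[C@@H](N(C)C)CN1c1c(F)cc2c(=O)c(C(=O)O)cn(C3CC3)c2c1F` differs from compound 2 in one place on the shared core: a group of 8 heavy atoms (6 carbon, 2 nitrogen; one four-membered non-aromatic ring with 1 hetero atom) in place of a group of 6 heavy atoms (4 carbon, 2 nitrogen; one four-membered non-aromatic ring with 1 hetero atom), on an aromatic carbon. Among the measured compounds shown here, no measured pair in this set shows the effect of such an exchange, so the expectation rests on the position of compound 2 alone. Compound 2 sits far below the other two, which leaves room for movement in either direction, but nothing here points to a large shift. The step from compound 2 to compound 4 in this assay is expected to be small, a 1.8-fold higher number from compound 2 to compound 4 (0.25 log units; within the scatter), perhaps a modest rise. Compound 4 is therefore estimated at 3 ug/mL, in a range from 1 ug/mL to 12 ug/mL.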

Compound 4, solubility: 97.1 ug/mL
Compound 4: the middle estimate sits 32-fold (1.51 log units) below what was measured, outside the stated range (above it).
By their numbers in this assay, from the lowest: compound 2; then compounds 3 and 1 (each within the scatter of the next); then compound 4.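

On the aromatic carbon ortho to two fluoro groups, the exchange of the 3-(methylamino)azetidin-1-yl group for the group with 8 heavy atoms gives a 57-fold higher number from compound 2 to compound 4 (1.76 log units; beyond the scatter) in this assay. Among the compounds shown here, this is the first pair in the set that differs in one place, and it shows that the read-out can respond strongly to what sits on this carbon. The exchange bundles several differences, since the entering group has 0 hydrogen-bond donors in place of 1, carries 2 defined stereocentres and has more heavy atoms, and nothing available here explains the size of the step.

Which of these differences carries the step remains open. A 3-(dimethylamino)azetidin-1-yl group without the ring methyl, or a methylamino group kept on the methyl-bearing ring, would separate the contribution of the amine from that of the ring substitution.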